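Cytotoxicity in MT2 cells: aryl change on the carbonyl

The source may report more compounds than this note shows. Statements on the series, on what has been measured and on what is new or still open speak of the compounds shown alone.

Measured compounds in an ADME assay on MT2 cells (Homo sapiens) for cytotoxicity, read by XTT assay, with a stated time of 4 days; a higher number here means that more compound is tolerated, a lower number that less compound is tolerated:
- compound 1 `Cc1ccccc1C(=O)N(Cc1ccco1)Cc1cc2cccc(C)c2[nH]c1=O` gives only a limit, > 64700 nM.
- compound 2 `Cc1ccc(C(=O)N(Cc2ccco2)Cc2cc3cccc(C)c3[nH]c2=O)cc1` gives 9200 nM.
- compound 3 `Cc1ccc2[nH]c(=O)c(CN(Cc3ccco3)C(=O)c3ccc(Br)cc3)cc2c1` gives only a limit, > 55400 nM.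

Compound 3 stands at a limit of this assay, not at a number (the limit of > 55400 nM in this assay, at which 1 of the 3 values shown sits). Compound 1 sits at a limit as well (the limit of > 64700 nM in this assay, at which 1 of the 3 values shown sits). Among the compounds with values here, compound 2 alone gives a number, and the one step counted between measured compounds, an at least 7.0-fold lower number from compound 1 to compound 2 (0.84 log units; beyond the scatter), runs from a limit to that number.

The next compound is compound 4 `Cc1ccc2[nH]c(=O)c(CN(Cc3ccco3)C(=O)c3ccc(Cl)c(Cl)c3)cc2c1`. It differs from compound 3 in one place: 3,4-dichlorophenyl in place of 4-bromophenyl on a carbonyl carbon. Within the data shown here, the only measured step sits at the same carbonyl carbon but swaps a different pair of aryl groups, so it does not speak directly to this change; it shows that an exchange of the aryl group at this place can move this assay at least modestly. With compound 3 at a limit, compound 4 is expected to stay near that ceiling, with a step of an at least 1.1-fold lower number from compound 3 to compound 4 (0.04 log units; that floor lies within the scatter), and its value in this assay is estimated at 50000 nM, within 15000 nM to 100000 nM.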

Compound 4, half-maximal cytotoxic concentration: 70700 nM
For compound 4 the middle estimate is 1.4-fold (0.15 log units) below the measured one; measured number inside the range.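

No new step can be read from compound 3 to compound 4, since compound 3 gives only a limit: the limit of > 55400 nM in this assay, at which 1 of the 4 values shown sits.

The compounds shown leave open how far 3,4-dichlorophenyl and 4-bromophenyl on the carbonyl carbon differ in this assay.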